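Swapping the triazole arm for a phenyltetrazole

This account rests on a few compounds, and the source may have more. Where it says the series, first, only, none or still open, it means among the compounds named here.

In a functional assay on C6 cells (Rattus norvegicus) for cytotoxicity, read by MTT assay, with a stated time of 24 h, tested at 6 ug/mL (on this read-out higher numbers stand for a weaker effect at the one concentration tested and lower numbers for a stronger effect), compound 1 `O=C(CSc1nnnn1-c1ccccc1)N/N=c1/scc(-c2ccc(Cl)cc2)n1-c1ccccc1` gives 77.4%, while compound 2 `Cn1cnnc1SCC(=O)N/N=c1/scc(-c2ccc(C#N)cc2)n1-c1ccccc1` gives 70.2%, a number that lies within the usual scatter of the value for compound 1. Compound 3 `N#Cc1ccc(-c2cs/c(=N/NC(=O)CSc3nnnn3-c3ccccc3)n2-c2ccccc2)cc1` has not yet been tested in this assay. It differs from compound 2 in one place: 1-phenyl-1H-tetrazol-5-yl in place of 4-methyl-4H-1,2,4-triazol-3-yl on a sulfur. Among the compounds with values here, no step between measured compounds isolates this change, so the expected step from compound 2 to compound 3 is a number 3.8 percentage points higher from compound 2 to compound 3 (within the scatter), none beyond the scatter. Compound 3 is therefore estimated at 74%, within 62% to 86%.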

Compound 3, a percentage reported as activity, at one concentration (the size of the read-out at that concentration, not a potency): 78.8%
Beside the measured number, compound 3's estimate is 4.8 percentage points below it, within the range that was stated.
By their numbers in this assay, from the lowest: compounds 2, 1 and 3 (each within the scatter of the next).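

On the sulfur, 1-phenyl-1H-tetrazol-5-yl in place of 4-methyl-4H-1,2,4-triazol-3-yl gives in this assay a number 8.6 percentage points higher from compound 2 to compound 3 (within the scatter) and so leaves the read-out inside the scatter despite the added six-membered aromatic ring. With that tetrazole arm held constant, cyano in place of chloro on an aromatic carbon gives a number 1.4 percentage points higher from compound 1 to compound 3 (within the scatter) and likewise shows no step beyond the scatter. Nothing measured here offers a reason for either step. The compounds shown leave open whether an amine or a carboxylic acid in place of these rings on the sulfur would give a step beyond the scatter.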